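Swapping methoxy for chloro in a sulfonamide series

The source may report more compounds than this note shows. Statements on the series, on what has been measured and on what is new or still open speak of the compounds shown alone.

Measured in a functional assay on A549 cells (Homo sapiens) for antiproliferative activity, read by MTT assay, with a stated time of 72 h; on this read-out higher numbers stand for weaker inhibition and lower numbers for stronger inhibition:
Compound 1 `COc1cccc(N2C(=O)COc3ccc(-c4cnc(Cl)c(NS(=O)(=O)c5ccc(F)cc5)c4)cc32)c1` gives 32700 nM
Compound 2 `O=C1COc2ccc(-c3cnc(Cl)c(NS(=O)(=O)c4ccc(F)cc4)c3)cc2N1C1CCCCC1` gives 37900 nM
Compound 3 `COc1ncc(-c2ccc3c(c2)N(c2ccccc2)C(=O)CO3)cc1NS(=O)(=O)c1ccc(F)cc1` gives 3490 nM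

Compound 3 has the lowest number of the three, and both other values lie well above it, beyond the scatter. Compound 4 `O=C1COc2ccc(-c3cnc(Cl)c(NS(=O)(=O)c4ccc(F)cc4)c3)cc2N1c1ccccc1` differs from it in one place: chloro in place of methoxy on an aromatic carbon. Among the measured compounds shown here, no measured step isolates this swap. The closest evidence is a 1.2-fold higher number from compound 1 to compound 2 (0.06 log units; within the scatter) for cyclohexyl in place of 3-methoxyphenyl on an amide-type nitrogen in a ring. Both of those compounds carry chloro, as compound 4 does, and that step stays within the scatter. A clear rise in this assay is therefore expected, towards compound 1 (32700 nM). The expected move is a 7.7-fold higher number from compound 3 to compound 4 (0.89 log units; beyond the scatter) (an estimate). The estimate for compound 4 is 27000 nM (range 10000 nM to 55000 nM).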

Compound 4, half-maximal inhibitory concentration: 14700 nM
Estimate against measurement, compound 4: 1.8-fold (0.26 log units) above, and the stated range covers the measured number.
By their numbers in this assay, from the lowest: compound 3; then compound 4; then compounds 1 and 2 (each within the scatter of the next).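

With the swap now isolated, chloro in place of methoxy next to the ring nitrogen gives a 4.2-fold higher number from compound 3 to compound 4 (0.62 log units; beyond the scatter) in this assay and so methoxy at this carbon goes with the stronger inhibition in this pair. The group on the amide-type nitrogen also matters, although compound 1 and compound 2 sit within the scatter of each other: phenyl in place of cyclohexyl gives a 2.6-fold lower number from compound 2 to compound 4 (0.41 log units; beyond the scatter) and dropping the methoxy from that group gives a 2.2-fold lower number from compound 1 to compound 4 (0.35 log units; beyond the scatter) with chloro kept throughout. As far as these compounds go, whether ethoxy or an amine at this carbon would match methoxy stays open. No measurement shown explains these differences.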